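This account rests on a few compounds, and the source may have more. Where it says the series, first, only, none or still open, it means among the compounds named here.

Measured compounds in a functional assay on MCF7 cells (Homo sapiens) for inhibition; on this read-out higher numbers stand for weaker inhibition and lower numbers for stronger inhibition:
- compound 1 `CC/C(=C(/c1ccc(/C=C/C(=O)O)cc1)c1cc2ccccc2[nH]1)c1ccccc1Cl`, 42 nM
- compound 2 `CC/C(=C(/c1ccc(/C=C/C(=O)O)cc1)c1cc2ccccc2[nH]1)c1ccccc1C#N`, 9 nM
- compound 3 `CC/C(=C(/c1ccc(/C=C/C(=O)O)cc1)c1cc2ccccc2[nH]1)c1cccc(F)c1C#N`, 40 nM

On these numbers compound 3 stands second highest of the three in this assay. Its nearest neighbour is compound 1: a 1.1-fold lower number from compound 1 to compound 3 (0.02 log units; within the scatter). Its furthest is compound 2: a 4.4-fold higher number from compound 2 to compound 3 (0.65 log units; beyond the scatter).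

Compound 4 `CC/C(=C(/c1ccc(/C=C/C(=O)O)cc1)c1cc2ccccc2[nH]1)c1ccc(Cl)cc1C#N` is the next member. The change from compound 3: 4-chloro-2-cyanophenyl in place of 2-cyano-3-fluorophenyl on a double-bonded chain carbon bound to a double-bonded chain carbon and a saturated chain carbon.

Going by the values given here, two measured steps bear on this. The fluoro that distinguishes compound 3 from compound 2 is removed again in compound 4, and that addition was costly: a 4.4-fold higher number from compound 2 to compound 3 (0.65 log units; beyond the scatter). The cyano in place of chloro had helped earlier: a 4.7-fold lower number from compound 1 to compound 2 (0.67 log units; beyond the scatter), and compound 4 keeps the cyano. Among the compounds with values here, no measured step covers a chloro entering the ring alongside the cyano, so that part is unknown. Taking the reversal of the fluoro step at less than full weight, the expected step in this assay is a modest move downward, a 2.2-fold lower number from compound 3 to compound 4 (0.35 log units; beyond the scatter). The estimate for compound 4 is 18 nM, with a range from 6 nM to 60 nM.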

Compound 4, half-maximal inhibitory concentration: 14 nM
For compound 4 the middle estimate is 1.3-fold (0.11 log units) above the measured one, within the range that was stated.
By their numbers in this assay, from the lowest: compounds 2 and 4 (each within the scatter of the next); then compounds 3 and 1 (each within the scatter of the next).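

In this assay, a halogen on the aryl group at this position need not carry a cost: with chloro in place of hydrogen, the result stays within the scatter (a 1.6-fold higher number from compound 2 to compound 4 (0.19 log units; within the scatter)). The exchange of 2-cyano-3-fluorophenyl for 4-chloro-2-cyanophenyl recovers part of the difference seen with the fluoro (a 2.9-fold lower number from compound 3 to compound 4 (0.46 log units; beyond the scatter)), and the nitrile-bearing group retains an advantage over 2-chlorophenyl even with chloro added (a 3.0-fold lower number from compound 1 to compound 4 (0.48 log units; beyond the scatter)). No measurement available here accounts for these differences.

The step from compound 3 changes both the halogen and its place on the ring, so the two contributions cannot be separated. Going by these compounds, how a methoxy group or an amine would compare with the chloro of 4-chloro-2-cyanophenyl remains open.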